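The source may hold more compounds than are shown below. What is called first, only, known or untested is meant among the compounds shown, and "the series" means these compounds.

In a physicochemical assay for solubility, read by HPLC, in phosphate buffer, with a stated time of 16 h, at pH 6.8 (a higher number here means a more soluble compound, a lower number a less soluble compound), the series reads as follows:

compound 1 `Cc1ccc([C@H](C)NC(=O)Cn2nnc3ccccc3c2=O)c(C)c1` gives 2700 nM
compound 2 `COc1ccc2nnn(CC(=O)N[C@@H](C)c3ccc(C)cc3)c(=O)c2c1` gives 2300 nM
compound 3 `COc1ccc2c(=O)n(CC(=O)N[C@@H](C)c3ccc(C)cc3)nnc2c1` gives 1000 nM

Compound 2 at 2300 nM lies within the scatter of compound 1 at 2700 nM. Against compound 3, compound 2 has the higher number, and the gap between them lies beyond the scatter.

Compound 4 `Cc1ccc([C@H](C)NC(=O)Cn2nnc3ccc(F)cc3c2=O)cc1` has not been measured. It differs from compound 2 by fluoro in place of methoxy on an aromatic carbon, on a six-membered aromatic ring of carbon only that is part of a fused or bridged system of two rings.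

Among the compounds with values here, no measured pair isolates this change, so neither size nor direction can be read from an existing step. Within the data shown here, the only guide is the spread of the three values, which runs from compound 3 at 1000 nM to compound 1 at 2700 nM and rests on very few compounds. In this assay no step beyond the scatter is expected, and no direction is favoured. The estimated move is a 1.1-fold higher number from compound 2 to compound 4 (0.04 log units; within the scatter) and is expected to stay within the scatter. For compound 4 the expected value is 2500 nM with an estimated range of 1000 nM to 6000 nM for the measurement.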

Compound 4, solubility: 3400 nM
The estimate for compound 4 lay 1.4-fold (0.13 log units) below the measured number; the range from low to high includes it.
By their numbers in this assay, from the lowest: compound 3; then compounds 2, 1 and 4 (each within the scatter of the next).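

In this assay, within the data shown here, fluoro in place of methoxy on an aromatic carbon gives a 1.5-fold higher number from compound 2 to compound 4 (0.17 log units; within the scatter), the first step that isolates a single change. At this place, meta to a fused ring and para to a fused ring, the exchange removes two heavy atoms and one hydrogen-bond acceptor and brings in one fluorine, yet the numbers for the pair do not separate beyond the scatter, so this pair alone fixes no direction for the change and shows only that the position tolerates it without a resolved step. No independent measurement bears on the reason for this result.

Among these compounds, open is whether other groups at the same place, such as a chloro group, a nitrile, an amine or a carboxylic acid, would give a step beyond the scatter, since methoxy and fluoro are the only two groups compared there. Also open, from the compounds shown here alone, is whether the same exchange of methoxy for fluoro on compound 3 would give a step of similar size.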